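Swapping a dihydroxypropyl triazole for a methylpiperazine chain

The compounds below may be only part of what the source reports. "The series", "measured", "known", "first", "only" and "open" are said of these compounds alone.

In a functional assay on MCF7 cells (Homo sapiens) for cytotoxicity, read by MTT assay, with a stated time of 72 h (on this read-out lower numbers stand for stronger inhibition and higher numbers for weaker inhibition), compound 1 `CN(C)CCCCCn1c2c(c3ccccc31)C(=O)c1c[n+]([O-])c3ccccc3c1C2=O`, which carries 4-(dimethylamino)butyl on a saturated chain carbon bound to an aromatic nitrogen, gives 200 nM. Compound 3 `O=C1c2c[n+]([O-])c3ccccc3c2C(=O)c2c1c1ccccc1n2Cc1cn(CC(O)CO)nn1`, which carries 1-(2,3-dihydroxypropyl)-1H-1,2,3-triazol-4-yl at that place, gives 1110 nM, the higher of the two exact numbers. Compound 2 `O=C1c2c[n+]([O-])c3ccccc3c2C(=O)c2c1c1ccccc1n2Cc1cn(C[C@H](O)CO)nn1` reads > 1000 nM, and this value is a limit of the assay. The stereo comparison gives a step that the limit leaves unreadable from compound 2 to compound 3.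

Compound 4 `CN1CCN(CCCCn2c3c(c4ccccc42)C(=O)c2c[n+]([O-])c4ccccc4c2C3=O)CC1` has 3-(4-methylpiperazin-1-yl)propyl in place of 1-(2,3-dihydroxypropyl)-1H-1,2,3-triazol-4-yl on a saturated chain carbon bound to an aromatic nitrogen, a change counted as 3-(4-methylpiperazin-1-yl)propyl in place of 1-(2,3-dihydroxypropyl)-1H-1,2,3-triazol-4-yl on a saturated chain carbon bound to an aromatic nitrogen. The closest evidence comes from the two measured steps that replace the 4-(dimethylamino)butyl of compound 1 with the triazole group: a 5.6-fold higher number from compound 1 to compound 3 (0.74 log units; beyond the scatter) and an at least 5.0-fold higher number from compound 1 to compound 2 (0.69 log units; beyond the scatter). Compound 4 again lacks the triazole group and has a saturated chain, so most of that modest difference is expected to be recovered, in the direction of a lower number in this assay. The methylpiperazine group itself has not been measured, so this expectation remains loose. The expected change is a 3.2-fold lower number from compound 3 to compound 4 (0.50 log units; beyond the scatter). For compound 4 the estimated value is 350 nM, with an expected range of 120 nM to 1000 nM.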

Compound 4, half-maximal inhibitory concentration: 100 nM
Estimate against measurement, compound 4: 3.5-fold (0.54 log units) above; the whole stated range lies above it.
By their numbers in this assay, from the lowest: compounds 4 and 1 (each within the scatter of the next); then compound 3.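

In this assay, among the compounds shown here, the change from the triazole group to 3-(4-methylpiperazin-1-yl)propyl, on a saturated chain carbon bound to an aromatic nitrogen, gives an 11-fold lower number from compound 3 to compound 4 (1.05 log units; beyond the scatter) and so is a large step, larger than the earlier steps between the chain of compound 1 and the triazole group had suggested for this position. The reading of compound 2 is a limit of the assay, so an at least 10-fold lower number from compound 2 to compound 4 (1.00 log units; beyond the scatter) is only a bound, though it points the same way. With a 2.0-fold lower number from compound 1 to compound 4 (0.30 log units; within the scatter) the two chains cannot be told apart here, which means 4-methylpiperazin-1-yl and (dimethylamino)methyl at this place both read on the same side of the gap that separates them from the triazole compounds, with no order between them.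

Nothing shown accounts for why the triazole group and the chains differ by this much. On these data alone, it remains open whether the step follows the terminal amine or the loss of the triazole, a question that a morpholine at the end of the butyl chain, or a dimethylamino group on the triazole in place of the dihydroxypropyl, would bear on.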